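This account rests on a few compounds, and the source may have more. Where it says the series, first, only, none or still open, it means among the compounds named here.

Compound 1 `CCCn1c(NC(=O)c2ccccn2)nc2cc(C(N)=O)cc(OC)c21` is the starting point of the set. In an assay for activation of interferon regulatory factor 3 (Homo sapiens), read by a luciferase reporter, with a stated time of 20 h (on this read-out lower numbers stand for an effect already at smaller amounts and higher numbers for an effect only at larger amounts of compound), compound 1 reaches only the limit of the assay and gives > 100000 nM. Compound 2 `CCCn1c(NC(=O)c2cccnn2)nc2cc(C(N)=O)cc(OC)c21` differs from it by pyridazin-3-yl in place of pyridin-2-yl on a carbonyl carbon. In this assay compound 2 likewise stops at a limit and gives > 100000 nM. The step that the two limits leave unreadable from compound 1 to compound 2 therefore cannot be read, because of the limit of > 100000 nM in this assay, at which 3 of the 3 values shown sit. Compound 3 `COCCCOc1cc(C(N)=O)cc2nc(NC(=O)c3ccccn3)n(CCCNC(=O)OCc3ccccc3)c12` has a core that differs from that of compound 1, but the difference between the two cores is not broken down here. In this assay compound 3 also returns a limit, > 100000 nM. Compound 4 `COCCCOc1cc(C(N)=O)cc2nc(NC(=O)c3cccnn3)n(CCCNC(=O)OCc3ccccc3)c12` is related to compound 3 by pyridazin-3-yl in place of pyridin-2-yl on a carbonyl carbon, the same change at the same place as that from compound 1 to compound 2. The step expected here is a step that the limit leaves unreadable from compound 3 to compound 4, resting on nothing more than the earlier step being unreadable and on (the limit of > 100000 nM in this assay, at which 3 of the 3 values shown sit). Compound 4 is accordingly expected to give about 150000 nM in this assay, within an estimated range from 50000 nM to 500000 nM, and most probably only a limit again.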

Compound 4, half-maximal effective concentration: > 100000 nM
Compound 4 was reported as a limit; the forecaster's own chance of this, stated with the estimate: 90%; the middle value does not contradict the limit.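

No new step can be read from compound 3 to compound 4 in this assay, because both compounds are reported only as limits: the limit of > 100000 nM in this assay, at which 4 of the 4 values shown sit.

The compounds shown leave open whether pyridazin-3-yl in place of pyridin-2-yl on a carbonyl carbon shifts this read-out at all, and how the four compounds rank against one another.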